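Removing a Methoxy Group from an Inactive Sulfonamide

The compounds below may be only part of what the source reports. "The series", "measured", "known", "first", "only" and "open" are said of these compounds alone.

Compound 1 `COc1cccc(N2C(=O)COc3ccc(-c4cnc(Cl)c(NS(=O)(=O)c5ccc(F)cc5)c4)cc32)c1` was tested in a functional assay on HCT-116 cells (Homo sapiens) for antiproliferative activity, read by MTT assay, with a stated time of 72 h; on this read-out higher numbers stand for weaker inhibition and lower numbers for stronger inhibition. In this assay compound 1 reaches only the limit of > 40000 nM, which is a boundary of the measurement rather than a number (the limit of > 40000 nM in this assay, at which 1 of the 2 values shown sits). A related compound 2 `COc1ccc(N2C(=O)COc3ccc(-c4cnc(OC)c(NS(=O)(=O)c5ccc(F)cc5)c4)cc32)cc1` gives 13400 nM in this assay. Compound 3 `O=C1COc2ccc(-c3cnc(Cl)c(NS(=O)(=O)c4ccc(F)cc4)c3)cc2N1c1ccccc1` differs from compound 1 by one change (hydrogen in place of methoxy on an aromatic carbon). Among the measured compounds shown here, no measured pair shows what this change does, so the expected step is a step that the limit leaves unreadable from compound 1 to compound 3, nothing beyond the usual scatter. Compound 3 is therefore estimated at 45000 nM, between 15000 nM and 150000 nM, with a good chance that again only a limit is reported.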

Compound 3, half-maximal inhibitory concentration: 39800 nM
Beside the measured number, compound 3's estimate is 1.1-fold (0.05 log units) above it; measured number inside the range.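

In this assay compound 1 stands only at a limit, > 40000 nM, and not at a number. With phenyl in place of 3-methoxyphenyl, compound 3 gives a true number, 39800 nM, so the methoxy group is not required for a measurable value on this core. Hydrogen in place of methoxy on an aromatic carbon gives a number no higher from compound 1 to compound 3 (the limit leaves the size open). How large the change is cannot be read: the limit of > 40000 nM in this assay, at which 1 of the 3 values shown sits.

Still open, on these data alone, is whether another group on this aromatic carbon, such as an amine or a fluorine atom, would give a clearly lower number in this assay.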